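Swapping Methoxy for Chloro: Expected Permeability of Compound 3

The source may report more compounds than this note shows. Statements on the series, on what has been measured and on what is new or still open speak of the compounds shown alone.

Going by the values given here, compound 2 `CC[C@@H](Nc1c(C#N)c(-c2ccc(-c3ccc(OC)cc3)cc2)nc2cnccc12)C(N)=O` holds the higher of the two numbers so far in an ADME assay on Caco-2 cells (Homo sapiens) for permeability, read by LC-MS, in the apical to basolateral direction, with a stated time of 2 h, tested at 2 uM; on this read-out higher numbers stand for higher permeability and lower numbers for lower permeability: compound 2 gives 114 nm/s, whereas compound 1 `CC[C@@H](Nc1c(C#N)c(-c2ccc(-c3cccc(Cl)c3F)cc2)nc2cnccc12)C(N)=O` gives 39 nm/s. Among the compounds with values here, the single measured step, a 2.9-fold higher number from compound 1 to compound 2 (0.47 log units; beyond the scatter), exchanged a ring bearing chloro and fluoro for one bearing methoxy. Compound 3 `CC[C@@H](Nc1c(C#N)c(-c2ccc(-c3ccc(Cl)cc3)cc2)nc2cnccc12)C(N)=O` differs from compound 2 by chloro in place of methoxy on an aromatic carbon. The measured step bears on this only loosely, as it moved two halogens out and a methoxy in, while here one chloro replaces the methoxy. Because compound 1 gives 39 nm/s with a chlorine on its outer ring, a modest fall from compound 2 is expected for compound 3, though one that may sit within the scatter. The estimate for compound 3 is 70 nm/s, with a range from 30 nm/s to 160 nm/s, meaning an expected step of a 1.6-fold lower number from compound 2 to compound 3 (0.21 log units; within the scatter).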

Compound 3, apparent permeability: 29 nm/s
Compound 3: middle estimate off by 2.4-fold (0.38 log units), on the high side; the whole stated range lies above it.
By their numbers in this assay, from the lowest: compounds 3 and 1 (each within the scatter of the next); then compound 2.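

On this aromatic carbon, para to a large group, changing only the substituent gives a 3.9-fold lower number from compound 2 to compound 3 (0.59 log units; beyond the scatter) in this assay, so exchanging methoxy for chloro alone is enough to move the number beyond the scatter. The other new comparison gives a 1.3-fold lower number from compound 1 to compound 3 (0.13 log units; within the scatter) and stays within the scatter, so the 4-chlorophenyl and 3-chloro-2-fluorophenyl groups cannot be told apart on this read-out, and compound 2 alone stands clear of the other two. Nothing measured here explains why the methoxy compound gives the higher number.

As far as these compounds go, it remains open whether that higher number is tied to methoxy alone or would also come with an ethoxy, a hydroxyl or an amine in the same place. Also open, from the compounds shown here alone, is whether the gap between methoxy and chloro would persist if the amide elsewhere in the molecule were changed.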